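Removing the meta-methyl from the anilide of compound 1

The source may report more compounds than this note shows. Statements on the series, on what has been measured and on what is new or still open speak of the compounds shown alone.

For the measured compounds named here, the three measured members share one core and differ only in the aryl group on the amide-type nitrogen. Compound 1 `Cc1cccc(NC(=O)C2(C(=O)Nc3ccc(Nc4ncc5cc(C(=O)N(C)C)n(C6CCCC6)c5n4)cc3)CC2)c1` gives 95.3% in a functional assay on T47D cells (Homo sapiens) for inhibition, read by CCK-8 assay, with a stated time of 72 h, tested at 10 uM (on this read-out higher numbers stand for more inhibition of growth at the one concentration tested and lower numbers for less inhibition of growth), the second highest of the three numbers. Compound 3 `CN(C)C(=O)c1cc2cnc(Nc3ccc(NC(=O)C4(C(=O)Nc5ccccc5F)CC4)cc3)nc2n1C1CCCC1` gives 97.8%, and the step of a number 2.5 percentage points higher from compound 1 to compound 3 (within the scatter) lies within the scatter. Compound 2 `CN(C)C(=O)c1cc2cnc(Nc3ccc(NC(=O)C4(C(=O)Nc5cccc(F)c5)CC4)cc3)nc2n1C1CCCC1` gives -0.4%, and the step of a number 95.7 percentage points lower from compound 1 to compound 2 (beyond the scatter) is large; likewise a number 98.2 percentage points higher from compound 2 to compound 3 (beyond the scatter).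

Compound 4 `CN(C)C(=O)c1cc2cnc(Nc3ccc(NC(=O)C4(C(=O)Nc5ccccc5)CC4)cc3)nc2n1C1CCCC1` differs from compound 1 by hydrogen in place of methyl on an aromatic carbon. The step to compound 2 shows that a fluoro at this position, in place of the methyl, removes the growth inhibition, while compound 3, which carries no group at this position at all, keeps it. Going by the values given here, no measured step removes the methyl on its own, so the direction of the change is read from compounds 2 and 3 together: a bare aromatic carbon here is compatible with high inhibition, as in compound 3, and only the fluoro-bearing compound 2 drops.

Compound 4 is therefore expected to stay near the high end, with the expected step of a number 13.3 percentage points lower from compound 1 to compound 4 (beyond the scatter) small and within the scatter, though with a wide range because compound 2 gives -0.4%. The estimate for compound 4 is 82%, between 30% and 99%.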

Compound 4, percent growth inhibition at one concentration: 93.9%
The estimate for compound 4 lay 11.9 percentage points below the measured number; the range from low to high includes it.
By their numbers in this assay, from the lowest: compound 2; then compounds 4, 1 and 3 (each within the scatter of the next).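

Direct removal of the methyl now has its own step in this assay, a number 1.4 percentage points lower from compound 1 to compound 4 (within the scatter), so the methyl on this aromatic carbon is not required for high growth inhibition at the concentration tested. The phenyl and 2-fluorophenyl anilides also cannot be separated, with a number 3.9 percentage points lower from compound 3 to compound 4 (within the scatter), which places hydrogen, the 3-methyl group and the 2-fluoro group in one high band across compounds 1, 3 and 4. Against this unsubstituted reference, the step of a number 94.3 percentage points higher from compound 2 to compound 4 (beyond the scatter) assigns the loss seen in compound 2 to the presence of fluoro at the position meta to the large group, not to the absence of methyl.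

No supporting data on hand explain why this one fluoro placement separates so sharply from hydrogen and methyl. As far as these compounds go, it remains open whether chloro, methoxy, an amine or a carboxylic acid on the same aromatic carbon would keep the inhibition or lose it as fluoro does, and a single-concentration read-out this high cannot show differences in potency among compounds 1, 3 and 4.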